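Sulfonamide triazole series: fluorophenyl variant of compound 3

The compounds below may be only part of what the source reports. "The series", "measured", "known", "first", "only" and "open" are said of these compounds alone.

Measured compounds, read in a functional assay on SGC-7901 cells (Homo sapiens) for antiproliferative activity, read by MTT assay, with a stated time of 24 h; on this read-out lower numbers stand for stronger inhibition and higher numbers for weaker inhibition:
- compound 1 `Cc1cccc(-n2cc(-c3cccc(NS(=O)(=O)c4c[nH]c(=O)[nH]c4=O)c3)nn2)c1`: 9100 nM
- compound 2 `O=c1[nH]cc(S(=O)(=O)Nc2cccc(-c3cn(-c4cccc(F)c4)nn3)c2)c(=O)[nH]1`: only a limit, > 20000 nM
- compound 3 `Cc1ccccc1-n1cc(-c2ccc(NS(=O)(=O)c3c[nH]c(=O)[nH]c3=O)cc2)nn1`: 13600 nM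

Compound 3 holds the highest of the two numbers shown in this assay. The nearest is compound 1, whose number is lower by a margin within the scatter, so the two are not ordered. Compound 2 sits at a limit, (the limit of > 20000 nM in this assay, at which 1 of the 3 values shown sits).

Compound 4 `O=c1[nH]cc(S(=O)(=O)Nc2ccc(-c3cn(-c4ccc(F)cc4)nn3)cc2)c(=O)[nH]1` is not yet measured. It differs from compound 3 by 4-fluorophenyl in place of 2-methylphenyl on an aromatic nitrogen. Among the compounds with values here, the one measured step that bears on this is an at least 2.1-fold higher number from compound 1 to compound 2 (0.34 log units; beyond the scatter), fluoro in place of methyl on an aromatic carbon, which moved the number upward and out to the limit. The present change also exchanges 2-methylphenyl for 4-fluorophenyl, so it is not a pure repeat of that step, but the direction is taken from it. An upward step, at least modest, is therefore expected as a 2.1-fold higher number from compound 3 to compound 4 (0.31 log units; beyond the scatter). For compound 4 the estimate in this assay is 28000 nM, with a range from 12000 nM to 60000 nM, and a real chance that only a limit is reported.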

Compound 4, half-maximal inhibitory concentration: > 20000 nM
Compound 4: only a limit was reported (the forecaster's own chance of this, stated with the estimate: 60%); the middle value is on the limit's open side.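

In this assay, replacing 2-methylphenyl with 4-fluorophenyl on the aromatic nitrogen gives an at least 1.4-fold higher number from compound 3 to compound 4 (0.16 log units; that floor lies within the scatter), so this position has now been changed directly, but the size of the change stays unfixed. For compound 4, > 20000 nM is a limit and not a number. Among the compounds shown, the fluorophenyl compounds, compound 2 and compound 4, are the two at the limit, while the methylphenyl compounds, compound 1 and compound 3, give numbers, and none goes against this: the limit of > 20000 nM in this assay, at which 2 of the 4 values shown sit.

The compounds shown do not separate the exchange of methyl for fluoro from the different placing on the phenyl ring, which 2-fluorophenyl or 4-methylphenyl on the same core would address. Also open, on these data alone, is whether an amine or a carboxylic acid on that phenyl ring would give a number rather than a limit.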